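Methylating the phenol of a pyrazole urea: an estimate

The source may hold more compounds than are shown below. What is called first, only, known or untested is meant among the compounds shown, and "the series" means these compounds.

Measured compounds and their values:
compound 1 `O=C(Nc1cccc(-n2cc(-c3ccncc3)c(-c3cc(O)cc(Cl)c3)n2)c1)Nc1ccc(Cl)c(C(F)(F)F)c1` gives -33%
compound 2 `O=C(Nc1cccc(-n2cc(-c3ccncc3)c(-c3cc(O)cc(Cl)c3)n2)c1)Nc1ccc(Cl)c(Cl)c1` gives -26%

Both measurements come from a functional assay on SNB-19 cells (Homo sapiens) for inhibition, read by sulforhodamine B assay, with a stated time of 48 h, tested at 100 uM; on this read-out higher numbers stand for a weaker effect at the one concentration tested and lower numbers for a stronger effect. Compound 1 and compound 2 share the same core and differ only in one group on the outer ring of the urea; the step of a number 7 percentage points higher from compound 1 to compound 2 (within the scatter) lies within the scatter, so on the numbers shown the two compounds stand together and neither can be called the stronger.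

Compound 3 `COc1cc(Cl)cc(-c2nn(-c3cccc(NC(=O)Nc4ccc(Cl)c(C(F)(F)F)c4)c3)cc2-c2ccncc2)c1` is the unmeasured compound. It is built from compound 1 by the change (methyl in place of hydrogen on an oxygen on an aromatic ring). Within the data shown here, the only measured step, from compound 1 to compound 2, touches a different part of the molecule, namely the chloro in place of trifluoromethyl, and was within the scatter; no measured pair shows what exchanging a hydroxy for a methoxy does here. There is therefore no ground in these data for expecting a step beyond the scatter in either direction.

For compound 3 the expected step is a number 11 percentage points higher from compound 1 to compound 3 (beyond the scatter). Compound 3 is estimated at -22%, with a range from -55% to 15%.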

Compound 3, a percentage reported as activity, at one concentration (the size of the read-out at that concentration, not a potency): -25%
Beside the measured number, compound 3's estimate is 3 percentage points above it; low and high end bracket the measured number.
By their numbers in this assay, from the lowest: compounds 1, 2 and 3 (each within the scatter of the next).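

Read in this assay, the swap of hydroxy to methoxy on the shared core gives a number 8 percentage points higher from compound 1 to compound 3 (within the scatter), so this single change cannot be told apart from the usual spread of repeat measurements. Among these compounds, this is the first measured change at this oxygen, as the earlier pair differed only in the chloro and trifluoromethyl groups on the outer ring of the urea. On this read-out, at this one concentration, the hydrogen on the oxygen can therefore be replaced by a methyl with no measurable consequence, although a larger effect from a different replacement cannot be ruled out. No measurement available here bears on what lies behind this result.

The compounds shown leave open whether a longer chain on this oxygen, such as ethyl or benzyl, or an amine in place of the hydroxy, would move the number beyond the scatter. They also leave open whether methoxy would behave the same way on the dichloro urea of compound 2, and how the compounds would compare across a range of concentrations rather than at a single one.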